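Oxanylamino-propenyl chain replacing the amino-methylbutyl chain

This account rests on a few compounds, and the source may have more. Where it says the series, first, only, none or still open, it means among the compounds named here.

Compound 3 `CC(C)(N)CCCN(C[C@H]1Cc2ccccc2CN1)[C@H]1CCCc2cccnc21` reaches in a functional assay on cells for agonist activity at C-X-C chemokine receptor type 4 (Homo sapiens), read by fluorescence and calcium flux, with a stated time of 90 s (on this read-out higher numbers stand for an effect only at larger amounts of compound and lower numbers for an effect already at smaller amounts), only a limit of the assay, > 30000 nM. Compound 1 `c1ccc2c(c1)CN[C@@H](CN(CCCCNCc1ccncc1)[C@H]1CCCc3cccnc31)C2` likewise gives only a limit, > 30000 nM. Compound 2 `c1ccc2c(c1)CN[C@@H](CN(CCCCNC1CCOCC1)[C@H]1CCCc3cccnc31)C2` also stays at a limit, > 30000 nM. All three values thus rest at the limit of > 30000 nM in this assay, at which 3 of the 3 values shown sit, so the steps a step that the two limits leave unreadable from compound 1 to compound 2, a step that the two limits leave unreadable from compound 1 to compound 3 and a step that the two limits leave unreadable from compound 2 to compound 3 cannot be sized. Compound 4 `C(=C/CN(C[C@H]1Cc2ccccc2CN1)[C@H]1CCCc2cccnc21)\CNC1CCOCC1` carries 3-((oxan-4-yl)amino)prop-1-en-1-yl in place of 3-amino-3-methylbutyl on a saturated chain carbon bound to an amine nitrogen. Among the compounds with values here, none of the measured steps bears readably on this change; compound 2 shares the oxan-4-yl amine and itself stayed at the limit. Compound 4 is therefore expected to remain at the limit as well, estimated 30000 nM within 10000 nM to 100000 nM. The expected step is accordingly a number no higher from compound 3 to compound 4 (the limit leaves the size open), of no readable size.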

Compound 4, half-maximal effective concentration: > 30000 nM
Compound 4: only a limit was reported (the forecaster's own chance of this, stated with the estimate: 80%); the middle value sits exactly at the limit.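

No step among compound 1, compound 2, compound 3 and compound 4 can be read in this assay, since all four give only a limit: the limit of > 30000 nM in this assay, at which 4 of the 4 values shown sit.

On these data alone, whether any chain on the shared core gives a measurable value remains open.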